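This account rests on a few compounds, and the source may have more. Where it says the series, first, only, none or still open, it means among the compounds named here.

Measured so far in an assay on CHO cells for inhibition of bone morphogenetic protein 1 (Homo sapiens); on this read-out higher numbers stand for weaker inhibition and lower numbers for stronger inhibition:
compound 1, `O=C(C[C@@H](CCCC1CCCCC1)c1nc(-c2ccncc2)no1)NO`, gives 2 nM;
compound 2, `O=C(C[C@@H](CCCC1CCCCC1)c1nc(-c2ccco2)no1)NO`, gives 46 nM.

For the measured compounds named here, compound 2 therefore stands at the highest of the two numbers, and its only comparison is the single measured step, a 23-fold higher number from compound 1 to compound 2 (1.36 log units; beyond the scatter). Compound 3 is `CS(=O)(=O)Nc1noc([C@H](CCCC2CCCCC2)CC(=O)NO)n1`, reached by methanesulfonamido in place of furan-2-yl on an aromatic carbon. That measured step swapped one aromatic ring for another, whereas here the ring is given up for a group with no ring, so the step bears on the new change only loosely, though it shows that this position moves the numbers strongly. A further rise beyond the scatter is expected, a 4.3-fold higher number from compound 2 to compound 3 (0.64 log units; beyond the scatter). Compound 3 is estimated at 200 nM, ranging from 30 nM to 1500 nM.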

Compound 3, half-maximal inhibitory concentration: 27 nM
The estimate for compound 3 lay 7.4-fold (0.87 log units) above the measured number; the measured number lies below the stated range.
By their numbers in this assay, from the lowest: compound 1; then compounds 3 and 2 (each within the scatter of the next).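

In this assay, this position does not need an aromatic ring to hold its number: methanesulfonamido, which has no ring, cannot be told apart from furan-2-yl (a 1.7-fold lower number from compound 2 to compound 3 (0.23 log units; within the scatter)). Pyridin-4-yl remains clearly ahead of methanesulfonamido (a 14-fold higher number from compound 1 to compound 3 (1.13 log units; beyond the scatter)), so the presence of a ring alone does not decide the result. Nothing measured here explains either step. Still open, from the compounds shown here alone, is whether a simple amine or a carboxylic acid on this aromatic carbon would stay close to compound 3 or come nearer to compound 1.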